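Cyano for Carbamoyl in a Series at the Assay Ceiling

The source may report more compounds than this note shows. Statements on the series, on what has been measured and on what is new or still open speak of the compounds shown alone.

Measured so far in a functional assay on KB cells (Homo sapiens) for cytotoxicity; a lower number here means a stronger inhibitor, a higher number a weaker inhibitor:
compound 1, `Cn1cc(C(N)=O)c2c(N)ncnc21`: compound 1 gives > 100000 nM, a limit of the assay.
compound 2, `Cn1cc(C#N)c2c(N)ncnc21`: compound 2 gives > 100000 nM, a limit of the assay.
compound 3, `COCCOCn1cc(C(N)=O)c2c(N)ncnc21`: compound 3 gives > 100000 nM, a limit of the assay.

All three values sit at the same limit, so neither measured step can be sized. The change cyano in place of carbamoyl on an aromatic carbon gives a step that the two limits leave unreadable from compound 1 to compound 2, and the change 2-methoxyethoxy in place of hydrogen on a saturated chain carbon bound to an aromatic nitrogen gives a step that the two limits leave unreadable from compound 1 to compound 3. Among the compounds with values here, that both steps stay unreadable follows from the limit of > 100000 nM in this assay, at which 3 of the 3 values shown sit, which is the only evidence on the measured steps.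

Compound 4, `COCCOCn1cc(C#N)c2c(N)ncnc21`, is not yet measured. It differs from compound 3 by cyano in place of carbamoyl on an aromatic carbon, which is the same kind of change as that from compound 1 to compound 2; the two differ in their surroundings, the ring atom bearing a methyl group (1 heavy atom) in the one case and a (2-methoxyethoxy)methyl group (6 heavy atoms) in the other. The same kind of change from compound 1 to compound 2 left the read-out at the limit, and compound 3 itself stands at the limit, so a step that the limit leaves unreadable from compound 3 to compound 4 is expected for compound 4, with the understanding that a value at the limit cannot show a step at all. Compound 4 is expected to give 150000 nM in this assay, the range 40000 nM to 600000 nM, and most likely to be reported only as a limit.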

Compound 4, half-maximal inhibitory concentration: > 100000 nM
Compound 4 was reported as a limit; the forecaster's own chance of this, stated with the estimate: 85%; the middle value does not contradict the limit.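

In this assay compound 4 gives > 100000 nM, a limit of the assay. No step can be read from compound 3 to compound 4 or from compound 2 to compound 4, because the values rest on one limit: the limit of > 100000 nM in this assay, at which 4 of the 4 values shown sit.

The compounds shown leave open how cyano and carbamoyl compare, and how methyl and (2-methoxyethoxy)methyl compare, on the shared core in a measurable range.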